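Hydrogen for Ethyl: An Expectation Built on a Single Limit

The source may hold more compounds than are shown below. What is called first, only, known or untested is meant among the compounds shown, and "the series" means these compounds.

compound 1, `CCC1(CCCCN2CCN(c3cccc(Cl)c3)CC2)C(=O)Nc2ccccc21`, in a functional assay on the whole organism (strain NMRI) with Mus musculus as the target, with stated times of 30 min and 5 min; on this read-out higher numbers stand for an effect only at larger amounts of compound and lower numbers for an effect already at smaller amounts: > 20 mg/kg, a limit of the assay
compound 2, `CCC1(CCCCN2CCN(c3ccc(Cl)c(Cl)c3)CC2)C(=O)Nc2ccccc21`, in this assay: "not determined" (no result reported)

Of the compounds shown here, two have been measured, and only one of them carries a result. In this assay compound 1 reaches the limit > 20 mg/kg, which is a boundary of the measurement and not a number. For compound 2 the entry in this assay stands as "not determined" (no result reported). Where compound 1 stands is therefore described entirely by the limit of > 20 mg/kg in this assay, at which 1 of the 2 values shown sits, and no step between two measured compounds exists that could show how large a structural change moves the read-out.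

Compound 3, `O=C1Nc2ccccc2C1CCCCN1CCN(c2cccc(Cl)c2)CC1`, differs from compound 1 by hydrogen in place of ethyl on a saturated ring carbon. No measured step tells how this change acts in this assay, so the expectation rests on the limit shown by compound 1 alone. Compound 3 is estimated at 30 mg/kg in this assay. The range for compound 3 is expected to run from 10 mg/kg to 100 mg/kg. The estimated step that the limit leaves unreadable from compound 1 to compound 3 is expected to stay within the scatter, and the most likely outcome for compound 3 is again a limit rather than a single number.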

Compound 3, minimum effective dose: > 10 mg/kg
Compound 3: only a limit was reported (the forecaster's own chance of this, stated with the estimate: 70%); the middle value lies beyond the limit too.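

Compound 1 and compound 3 are both reported in this assay only as limits of the assay, so no step can be read for hydrogen in place of ethyl on a saturated ring carbon. The compounds shown leave open whether this exchange changes the minimum effective dose at all, and in which direction.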